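This account rests on a few compounds, and the source may have more. Where it says the series, first, only, none or still open, it means among the compounds named here.

Measured so far:
Compound 1, `Nc1nc(O)c2c(n1)n(C1OC(CO)[C@@H](O)[C@H]1O)c(=O)n2CC(O)CSc1ccccc1`, 12%
Compound 2, `COc1ccc(Cn2c(=O)n(C3OC(CO)[C@@H](O)[C@H]3O)c3nc(N)nc(O)c32)cc1`, 44%
Compound 3, `CCOC(=O)Cn1c(=O)n(C2OC(CO)[C@@H](O)[C@H]2O)c2nc(N)nc(O)c21`, 86%

In a functional assay on the whole organism (B cells) with Mus musculus as the target (on this read-out lower numbers stand for smaller maximal responses and higher numbers for larger maximal responses), compound 3 stands highest of the three measured compounds; compound 2 sits a number 42 percentage points higher from compound 2 to compound 3 (beyond the scatter), and compound 1 a number 74 percentage points higher from compound 1 to compound 3 (beyond the scatter). Compound 4, `CCn1c(=O)n(C2OC(CO)[C@@H](O)[C@H]2O)c2nc(N)nc(O)c21`, has not been measured yet. Its difference from compound 3 is methyl in place of ethoxycarbonyl on a saturated chain carbon bound to an aromatic nitrogen. All three measured steps change the group at this same place, and all are large: a number 32 percentage points higher from compound 1 to compound 2 (beyond the scatter) and the two steps to compound 3 just given. None of them, however, replaces ethoxycarbonyl with methyl, so the size of the coming step is uncertain. Within the data shown here, since every change at this position so far moved the number well beyond the scatter, compound 4 is expected to show a step of a number 21 percentage points lower from compound 3 to compound 4 (beyond the scatter), with a broad range. The estimate for compound 4 is 65%, between 35% and 95%.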

Compound 4, largest response reached (reported as maximal response), in percent of the reference or control that the assay uses: 82%
Compound 4: middle estimate off by 17 percentage points, on the low side; measured number inside the range.
By their numbers in this assay, from the lowest: compound 1; then compound 2; then compounds 4 and 3 (each within the scatter of the next).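

In this assay, methyl in place of ethoxycarbonyl gives a number 4 percentage points lower from compound 3 to compound 4 (within the scatter), so at this place the single carbon of methyl serves as well as the larger ester group. Methyl also gives a number 38 percentage points higher from compound 2 to compound 4 (beyond the scatter) and a number 70 percentage points higher from compound 1 to compound 4 (beyond the scatter), which ties the lower numbers to 4-methoxyphenyl and 1-hydroxy-2-(phenylsulfanyl)ethyl, and shows that a change at this place need not move the number. No measurement given here explains these differences. From the compounds shown here alone, whether a propyl chain, an amine or a carboxylic acid at this place would stay level with methyl remains open.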